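The source may hold more compounds than are shown below. What is called first, only, known or untested is meant among the compounds shown, and "the series" means these compounds.

Measured compounds:
compound 1, `Cc1ccc(Cn2c(=O)n(CC(C)(C)C(=O)O)c(=O)[nH]/c2=N\c2ccc(OC(C)C)c(Cl)c2)cc1`, gives 0.01 in an ADME assay on the whole organism (plasma, Rattus norvegicus) for protein binding, using cassette dosing, at a dose of 1 mg/kg; a higher number here means a larger unbound share of the compound, a lower number a smaller unbound share;
compound 2, `Cc1ccc(Cn2c(=O)n(C[C@H](C)C(=O)O)c(=O)[nH]/c2=N\c2ccc(OC(C)C)c(Cl)c2)cc1`, gives 0.014 in this assay;
compound 3, `CC(C)Oc1ccc(/N=c2\[nH]c(=O)n(C[C@H](C)C(=O)O)c(=O)n2Cc2ccc(Cl)cc2)cc1Cl`, gives 0.003 in this assay.

The not yet measured compound 4 is `CC(C)Oc1ccc(/N=c2\[nH]c(=O)n(CC(C)(C)C(=O)O)c(=O)n2Cc2ccc(Cl)cc2)cc1Cl`. Compound 1 and compound 2 share a core and differ by 1-carboxy-1-methylethyl in place of 1-carboxyethyl on a saturated chain carbon bound to an aromatic nitrogen; that change made a step of a 1.4-fold lower number from compound 2 to compound 1 (0.15 log units; within the scatter). Compound 4 is built from compound 3 by the same change, (1-carboxy-1-methylethyl in place of 1-carboxyethyl on a saturated chain carbon bound to an aromatic nitrogen), at the same place. The two cores differ by chloro in place of methyl on an aromatic carbon, which made a step of a 4.7-fold lower number from compound 2 to compound 3 (0.67 log units; beyond the scatter), so compound 3 already stands at the low end of these three numbers.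

Going by the values given here, since the one earlier instance of this change, from compound 2 to compound 1, stayed within the scatter, the step from compound 3 to compound 4 in this assay is expected to be of similar small size, a 1.2-fold lower number from compound 3 to compound 4 (0.08 log units; within the scatter). Among the compounds with values here, with only a single prior example, this rests on thin ground. Compound 4 is therefore estimated at 0.0025, with a likely range from 0.001 to 0.006.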

Compound 4, unbound fraction: 0.003
For compound 4 the middle estimate is 1.2-fold (0.08 log units) below the measured one; low and high end bracket the measured number.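

In this assay, putting 1-carboxy-1-methylethyl in place of 1-carboxyethyl gives no change at the digits printed from compound 3 to compound 4 (within the scatter), and this swap carries over from one core to the other: the same change on two cores in this assay, a 1.4-fold lower number (0.15 log units; within the scatter) from compound 2 to compound 1 and no change at the digits printed (within the scatter) from compound 3 to compound 4, 1.4-fold (0.15 log units) apart, within the scatter of two such steps. The change of chloro in place of methyl on an aromatic carbon, now seen on a second pair, gives a 3.3-fold lower number from compound 1 to compound 4 (0.52 log units; beyond the scatter), and it too repeats: the same change on two cores in this assay, a 4.7-fold lower number (0.67 log units; beyond the scatter) from compound 2 to compound 3 and a 3.3-fold lower number (0.52 log units; beyond the scatter) from compound 1 to compound 4, 1.4-fold (0.15 log units) apart, within the scatter of two such steps. This shows that, in these four compounds, each change has much the same size on both backgrounds, but the chain swap stays within the scatter both times, so it does not show that the swap has any real effect on the unbound fraction, and two pairs cannot vouch for other cores.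

Going by these compounds, it remains open whether the same holds with a methoxy group or a trifluoromethyl group in place of the chloro or methyl. Also open, on these data alone, is what a longer chain carrying the carboxy group, or an amide in place of that group, would do to this number.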